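This account rests on a few compounds, and the source may have more. Where it says the series, first, only, none or still open, it means among the compounds named here.

Compound 1 `NS(=O)(=O)c1ccc(S(=O)(=O)Nc2cccc(-c3nc(-c4ccc(NC(=O)c5cccnc5)cc4Cl)no3)c2)cc1` carries the shared core of this small set and in a functional assay on MDA-MB-231 cells (Homo sapiens) for antiproliferative activity, read by MTT assay, with a stated time of 72 h (on this read-out higher numbers stand for weaker inhibition and lower numbers for stronger inhibition), gives > 10000 nM, which is a limit of the assay rather than a number. Compound 2 `O=C(Nc1ccc(-c2noc(-c3cccc(NS(=O)(=O)c4ccc(NC(=O)N5CCCC5)cc4)c3)n2)c(Cl)c1)c1cccnc1` gives 5800 nM in this assay. For the measured compounds named here, the single-place change between these two, an at least 1.7-fold lower number from compound 1 to compound 2 (0.23 log units; that floor lies within the scatter), is the only measured step available, and its size is a floor that lies within the scatter. Compound 3 `O=C(Nc1ccc(Cl)cc1)Nc1cccc(-c2nc(-c3ccc(NC(=O)c4cccnc4)cc3Cl)no2)c1` gives > 10000 nM in this assay, again a limit. the limit of > 10000 nM in this assay, at which 2 of the 3 values shown sit, shows where compound 3 stands: at the limit, with no number beneath it. Compound 4 `CS(=O)(=O)Nc1cccc(NC(=O)Nc2cccc(-c3nc(-c4ccc(NC(=O)c5cccnc5)cc4Cl)no3)c2)c1` has not yet been measured. It differs from compound 3 by 3-(methanesulfonamido)phenyl in place of 4-chlorophenyl on an amide-type nitrogen. Going by the values given here, no measured step covers this change directly; the step from compound 1 to compound 2 concerns a different group at a different place, and it was itself only a floor within the scatter. Compound 4 is therefore expected to show no step beyond the scatter, with an estimated value of 12000 nM, between 4000 nM and 40000 nM. The step this expectation means is a step that the limit leaves unreadable from compound 3 to compound 4, with a fair chance that the assay again reports only a limit.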

Compound 4, half-maximal inhibitory concentration: > 10000 nM
Compound 4: a limit, no number; the forecaster's own chance of this, stated with the estimate: 65%; the middle value lies beyond the limit too.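

Compound 3 and compound 4 both end at a limit of the assay in this assay, so no step can be read between them: the limit of > 10000 nM in this assay, at which 3 of the 4 values shown sit.

The compounds shown leave open whether 3-(methanesulfonamido)phenyl in place of 4-chlorophenyl on an amide-type nitrogen changes the read-out at all, since neither compound has a number to compare.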